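The source may report more compounds than this note shows. Statements on the series, on what has been measured and on what is new or still open speak of the compounds shown alone.

Notes on a small series tested in an ADME assay on HepG2 2.2.15 cells (Homo sapiens) for cytotoxicity; a higher number here means that more compound is tolerated, a lower number that less compound is tolerated. Compound 1 `O=C(Nc1ncc(Cc2ccc(Br)cc2)s1)c1cccs1` gives > 50000 nM, which is a limit of the assay and not a number. Compound 2 `COc1ccc(COC(c2ccccc2)c2cnc(NC(=O)c3cccs3)s2)cc1` is recorded in this assay as "not toxic" (no number reported). Compound 3 `COCCNc1ncc(C(Oc2ccc3cc(Br)ccc3c2)c2ccc(Cl)cc2)s1` likewise stands in this assay at "not toxic" (no number reported), so no single number places it against the others; of the three entries, (the limit of > 50000 nM in this assay, at which 1 of the 3 values shown sits), and two carry no number. Compound 4 `O=C(Nc1ncc(C(Oc2ccc3cc(Br)ccc3c2)c2ccc(Cl)cc2)s1)c1ccc(Br)cc1` is not yet measured. It differs from compound 3 by (4-bromophenyl)carbonyl in place of 2-methoxyethyl on a nitrogen on an aromatic ring. For the measured compounds named here, no measured step anchors the size of this change, so in this assay a shift of modest size toward a lower tolerated concentration is expected, if any beyond the scatter. The half-maximal cytotoxic concentration of compound 4 is estimated at 40000 nM, with a range from 10000 nM to 100000 nM.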

Compound 4, half-maximal cytotoxic concentration: > 50000 nM
Compound 4: no number, only a limit; the forecaster's own chance of this, stated with the estimate: 50%; at least 1.2-fold (0.09 log units) between middle value and limit.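

In this assay compound 4 gives > 50000 nM, which is a limit and not a number. For the compounds shown here, compound 3 has no single number, so no step between compound 3 and compound 4 can be read. The compounds shown leave open the actual half-maximal cytotoxic concentration of all four compounds.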